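A change on an amide-type nitrogen, and what to expect

The source may hold more compounds than are shown below. What is called first, only, known or untested is meant among the compounds shown, and "the series" means these compounds.

Measured so far:
- compound 1, `COc1ccc(N(C)C(=O)N(C)c2cc(OC)c(OC)c(OC)c2)cc1`: >= 125000 nM
- compound 2, `COc1cc(NC(=O)c2ccc(F)cc2)cc(OC)c1OC`: >= 125000 nM
- compound 3, `COc1cc(NC(=O)Nc2cccc3c2CCC3)cc(OC)c1OC`: >= 125000 nM

All three measured compounds were tested in a functional assay on ONS-76 cells (Homo sapiens) for cytotoxicity, read by MTT assay, with a stated time of 72 h; on this read-out lower numbers stand for stronger inhibition and higher numbers for weaker inhibition. For compound 1 the figure >= 125000 nM is not a number but the limit of the assay, meaning no inhibition was seen up to the highest concentration tried. The same holds for compound 2, whose value >= 125000 nM is a limit. Compound 3 also sits at the limit with >= 125000 nM. In short, every value shown is a limit, as summarised by the limit of >= 125000 nM in this assay, at which 3 of the 3 values shown sit, so compound 1 cannot be placed above or below any other compound on these numbers.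

Compound 4, `COc1cc(N(C)C(=O)N(C)c2cccc(F)c2)cc(OC)c1OC`, has not yet been measured in this assay. It differs from compound 1 in one place: 3-fluorophenyl in place of 4-methoxyphenyl on an amide-type nitrogen. For the measured compounds named here, with no measured step available to compare, and with compound 1 itself at the limit, the expectation for compound 4 is that the step of a number no higher from compound 1 to compound 4 (the limit leaves the size open) stays within the scatter, most likely again at the limit. Compound 4 is therefore estimated at 125000 nM, in the range 30000 nM to 300000 nM.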

Compound 4, half-maximal inhibitory concentration: >= 125000 nM
Compound 4: no number, only a limit; the forecaster's own chance of this, stated with the estimate: 75%; the middle value lies on the limit itself.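

Compound 1 and compound 4 both give only a limit and no number, so no step can be read between them: the limit of >= 125000 nM in this assay, at which 4 of the 4 values shown sit.

The compounds shown leave open whether 3-fluorophenyl or 4-methoxyphenyl on an amide-type nitrogen makes any difference, and which change, if any, would bring measurable inhibition.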